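From phenyl to 3,4-difluorophenyl: compound 2 to compound 3

The source may hold more compounds than are shown below. What is called first, only, known or untested is meant among the compounds shown, and "the series" means these compounds.

In an ADME assay on HepG2 cells (Homo sapiens) for inhibition, read by resazurin assay, with a stated time of 48 h (on this read-out higher numbers stand for an effect only at larger amounts of compound and lower numbers for an effect already at smaller amounts), compound 2 (`O=C(Nc1ccc2sc(-c3ccccc3)nc2c1)N1CCCCC1`) gives > 50000 nM as a limit and not a number. Compound 1 (`O=C(Nc1ccc2sc(-c3ccc(F)c(F)c3)nc2c1)N1CCC(F)CC1`) carries 3,4-difluorophenyl and gives > 50000 nM as a limit as well. Both values shown therefore stand at one point: the limit of > 50000 nM in this assay, at which 2 of the 2 values shown sit, marks where the series sits so far, and compound 2 has no exact position on the scale.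

Compound 3 (`O=C(Nc1ccc2sc(-c3ccc(F)c(F)c3)nc2c1)N1CCCCC1`) has 3,4-difluorophenyl in place of phenyl on an aromatic carbon of the five-membered aromatic ring with 1 nitrogen and 1 sulfur. No measured step sizes this change. The expected step of a number no higher from compound 2 to compound 3 (the limit leaves the size open) is none beyond the scatter in this assay and has no expected direction. Compound 3 is estimated at 50000 nM with an expected range from 25000 nM to 100000 nM and will most likely be reported as a limit again.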

Compound 3, half-maximal effective concentration: > 50000 nM
Compound 3 gave a limit, no number; the forecaster's own chance of this, stated with the estimate: 85%; the middle value sits exactly at the limit.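

In this assay compound 3 gives > 50000 nM, a limit and not a number. No step from compound 1 or compound 2 to compound 3 can be read: the limit of > 50000 nM in this assay, at which 3 of the 3 values shown sit.

The compounds shown leave open where any of them lies on the scale, and whether either change shifts the value at all.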